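The source may report more compounds than this note shows. Statements on the series, on what has been measured and on what is new or still open speak of the compounds shown alone.

Working notes on the series: three compounds have values so far. In a functional assay on K562 cells (Homo sapiens) for antiproliferative activity, read by MTT assay, with a stated time of 48 h (a lower number here means a stronger inhibitor, a higher number a weaker inhibitor), compound 1 `COc1ccc(-c2ccc3c(c2)C(=O)C(=O)N3Cc2ccc(C(F)(F)F)cc2)cc1` gives 270 nM and compound 3 `COc1ccc(CN2C(=O)C(=O)c3cc(-c4cc(OC)cc(OC)c4)ccc32)cc1` gives 510 nM. These two values lie within the scatter of each other, so compound 3 stands level with compound 1 on the available numbers. Compound 2 `COc1ccc(CN2C(=O)C(=O)c3c(-c4ccc(OC)cc4)cccc32)cc1` reads > 10000 nM in this assay, which is a limit of the assay and not a number.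

The next compound is compound 4 `COc1ccc(CN2C(=O)C(=O)c3cc(-c4ccc(Cl)cc4)ccc32)cc1`. It has 4-chlorophenyl in place of the 3,5-dimethoxyphenyl of compound 3, on an aromatic carbon, and keeps the rest of the structure (4-chlorophenyl in place of 3,5-dimethoxyphenyl on an aromatic carbon).

Going by the values given here, no pair of measured compounds differs in one place only, so the size of this change has no direct precedent in this assay. The expectation rests on compound 3 at 510 nM and on compound 1 at 270 nM, which carry different aryl groups and still give values within the scatter of each other. The limit seen for compound 2 shows that a much weaker result in this series cannot be excluded, so the upper side of the range is kept wide. The expected size of a 1.0-fold lower number from compound 3 to compound 4 (0.01 log units; within the scatter) is none beyond the scatter. For compound 4 the estimated value is 500 nM, with an expected range of 150 nM to 2500 nM.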

Compound 4, half-maximal inhibitory concentration: 230 nM
Beside the measured number, compound 4's estimate is 2.2-fold (0.34 log units) above it; measured number inside the range.
By their numbers in this assay, from the lowest: compounds 4, 1 and 3 (each within the scatter of the next, the first and the last beyond it). At a limit, above all of these: compound 2.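

In this assay, going by these compounds alone, the exchange of 3,5-dimethoxyphenyl for 4-chlorophenyl gives a 2.2-fold lower number from compound 3 to compound 4 (0.35 log units; beyond the scatter), and this is the first step between compounds that differ in one place. It shows that the aryl group on this aromatic carbon can be changed with a modest shift in the number, and that the shift here is towards the stronger side. The entering group has fewer heavy atoms than the leaving group and no hydrogen-bond acceptors, so the two methoxy groups of compound 3 are not needed for a value of this order in this assay.

From the compounds shown here alone, this single step cannot separate the loss of the methoxy groups from the entry of chlorine, and it remains open whether an amine or a carboxylic acid on the same aryl ring would hold the value. Compound 2 remains a limit and not a number, so what separates it from the other compounds stays unresolved: the limit of > 10000 nM in this assay, at which 1 of the 4 values shown sits.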